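Swapping the ester for hydroxymethyl on a cyclopropane-type core

The source may report more compounds than this note shows. Statements on the series, on what has been measured and on what is new or still open speak of the compounds shown alone.

Measured in a functional assay on A549 cells (Homo sapiens) for cytotoxicity, read by MTT assay, with a stated time of 48 h; on this read-out lower numbers stand for stronger inhibition and higher numbers for weaker inhibition:
Compound 1 `COc1cc([C@@H]2C[C@@]2(CO)C(=O)Nc2ccccc2)cc(OC)c1OC`: 43200 nM
Compound 2 `CCOC(=O)[C@@]1(C(=O)Nc2ccccc2)C[C@@H]1c1cc(OC)c(OC)c(OC)c1`: > 100000 nM
Compound 3 `CCOC(=O)[C@]1(C(=O)Nc2ccccc2)C[C@@H]1c1cc(OC)c(OC)c(OC)c1`: 21300 nM

Compound 2 gives > 100000 nM, which is a limit of the assay and not a number. The account therefore starts from the limit of > 100000 nM in this assay, at which 1 of the 3 values shown sits, and compound 2 has no exact position on the scale.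

The next compound is compound 4 `COc1cc([C@H]2C[C@@]2(CO)C(=O)Nc2ccccc2)cc(OC)c1OC`, still to be measured in this assay. It carries hydroxymethyl in place of ethoxycarbonyl on a saturated ring carbon.

Only one measured step links two of these compounds, and it is an at least 4.6-fold lower number from compound 2 to compound 3 (0.67 log units; beyond the scatter). It involves no exchange of groups, given (the fact that compounds 2 and 3 differ only in the configuration as drawn), so it does not measure this change directly. It does show that configuration alone can move the number in this pair, and that argues for a wide range.

The closest guide is compound 1, which also carries hydroxymethyl and gives 43200 nM. Within the data shown here, a lower number than the limit of the starting compound is therefore expected, though no measured step shows its size.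

The expected change is an at least 2.5-fold lower number from compound 2 to compound 4 (0.39 log units; beyond the scatter).

For compound 4 the estimated value is 40000 nM, with an expected range of 14000 nM to 100000 nM.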

Compound 4, half-maximal inhibitory concentration: > 100000 nM
Compound 4: a limit, no number (the forecaster's own chance of this, stated with the estimate: 25%); middle value at least 2.5-fold (0.39 log units) from the limit.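

In this assay compound 4 gives > 100000 nM, which is a limit of the assay and not a number. Compound 2 also stands at a limit, so the step for hydroxymethyl in place of ethoxycarbonyl on a saturated ring carbon cannot be read, and carrying hydroxymethyl at this position does not by itself give a measurable value. The new information lies in the hydroxymethyl pair, which shows an at least 2.3-fold higher number from compound 1 to compound 4 (0.36 log units; beyond the scatter), so configuration moves the number with hydroxymethyl as well as with ethoxycarbonyl, and the difference in this pair can be traced to configuration alone: the fact that compounds 1 and 4 differ only in the configuration as drawn

From the compounds shown here alone, the size of the exchange between ethoxycarbonyl and hydroxymethyl remains open, as does whether it would favour either group in a pair where both values are numbers. Also open, going by these compounds, is how a carboxylic acid, an aminomethyl group or a longer alkoxycarbonyl chain on this saturated ring carbon would read in this assay, and whether configuration would matter as much with those groups.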